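This account rests on a few compounds, and the source may have more. Where it says the series, first, only, none or still open, it means among the compounds named here.

Of the compounds shown here, two have been measured here. Compound 1 `Cc1ccc(NC(=O)C(=O)Nc2ccc(OCC(=O)O)c(F)c2)cc1` and compound 2 `O=C(O)COc1ccc(NC(=O)c2ccccc2)cc1F` share a core that carries a fluorine and an oxyacetic acid, and they differ in the group attached to the amide-type nitrogen on that core. In a functional assay on CHO cells for agonist activity at Free fatty acid receptor 1 (Homo sapiens), read by FLIPR, tested at 300 nM (on this read-out lower numbers stand for a weaker effect and higher numbers for a stronger effect at the one concentration tested), compound 1 gives 29.9%. In this assay compound 2 gives 12.8%, the lower of the two numbers, and the gap between compound 2 and compound 1 lies beyond the usual scatter.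

Compound 3 `O=C(O)COc1ccc(NC(=O)Nc2ccccc2)cc1F` is not yet measured. It differs from compound 2 in one place: anilino in place of phenyl on a carbonyl carbon. The change adds a single hydrogen-bond donor and leaves everything else untouched.

Among the measured compounds shown here, no measured pair shows exactly this kind of change, so the expectation rests on the two numbers above. Compound 1, which also carries a second amide-type nitrogen, sits clearly higher than compound 2 in this assay; on that basis the step from compound 2 to compound 3 is expected to be a moderate rise, a number 9.2 percentage points higher from compound 2 to compound 3 (within the scatter), not more than the gap already seen. Compound 3 is therefore estimated to give 22% in this assay, with a likely range from 8% to 40%.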

Compound 3, a percentage reported as activity, at one concentration (the size of the read-out at that concentration, not a potency): 23.7%
The estimate for compound 3 lay 1.7 percentage points below the measured number; measured number inside the range.
By their numbers in this assay, from the lowest: compound 2; then compounds 3 and 1 (each within the scatter of the next).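

In this assay, among the compounds shown here, putting anilino in place of phenyl on a carbonyl carbon gives a number 10.9 percentage points higher from compound 2 to compound 3 (beyond the scatter) and so provides the first comparison here in which only one place changes. The step is modest, but it shows that the read-out responds to what is attached at this position, and that anilino is tolerated there without any loss of effect at the one concentration tested. Anilino brings a nitrogen and a hydrogen-bond donor that phenyl lacks, yet nothing shown here explains the rise.

A single step cannot show whether the gain depends on the new amide-type nitrogen and its hydrogen or simply on having one more atom before the ring, so a benzyl group or a phenoxy group on the same carbonyl carbon would be the telling comparison. Also open, as far as these compounds go, is how anilino would behave with a methyl or methoxy group on its ring, and whether the step would hold at other concentrations, since one concentration gives the size of an effect and not a potency.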